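A few compounds are considered here, and "the series" means these few. Any claim that something is new, unique, unknown or untested is made for them only; others in the source may bear on it.

Measured compounds:

Compound 1, `Cc1cccc(Nc2nccc(-c3ccccn3)n2)c1`, gives 700 nM in a functional assay for inhibition, with Homo sapiens as the target; a lower number here means a stronger inhibitor, a higher number a weaker inhibitor.
Compound 2, `CCc1cccc(Nc2nccc(-c3ccccn3)n2)c1`, gives 1400 nM.
Compound 3, `COc1cccc(Nc2nccc(-c3ccccn3)n2)c1`, gives 200 nM.

Compound 2 shows the highest number of the three. Its nearest neighbour is compound 1: the step of a 2.0-fold higher number from compound 1 to compound 2 (0.30 log units; within the scatter) lies within the scatter, so the two cannot be told apart. Compound 3 stands further off, with a 7.0-fold lower number from compound 2 to compound 3 (0.85 log units; beyond the scatter) and also a 3.5-fold lower number from compound 1 to compound 3 (0.54 log units; beyond the scatter), both beyond the scatter. All three measured steps change only the small group on the outer benzene ring, with the rest of the molecule held the same.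

Compound 4, `CCc1cccc(Nc2nccc(-c3ccco3)n2)c1`, differs from compound 2 in another place: furan-2-yl in place of pyridin-2-yl on an aromatic carbon. For the measured compounds named here, none of the measured steps touches this part of the molecule, so the data give no direct guide to the size or direction of the step in this assay. The only firm point is the value of compound 2 itself, and the step to compound 4 is expected to be of the same order as the measured steps, but its direction is uncertain. The estimate for compound 4 is 3000 nM, with a range from 700 nM to 15000 nM, which corresponds to an expected step of a 2.1-fold higher number from compound 2 to compound 4 (0.33 log units; beyond the scatter).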

Compound 4, half-maximal inhibitory concentration: 9700 nM
For compound 4 the middle estimate is 3.2-fold (0.51 log units) below the measured one, and the stated range covers the measured number.
By their numbers in this assay, from the lowest: compound 3; then compounds 1 and 2 (each within the scatter of the next); then compound 4.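

In this assay, this position proves sensitive to the choice of ring: with the ethyl group on the outer benzene ring held the same, furan-2-yl in place of pyridin-2-yl gives a 6.9-fold higher number from compound 2 to compound 4 (0.84 log units; beyond the scatter). For the compounds shown here, this step lies beyond the scatter and is about as large as the largest step among the earlier compounds, a 7.0-fold lower number from compound 2 to compound 3 (0.85 log units; beyond the scatter), so changes at this position can matter as much as those on the outer ring. The two groups have the same counts of hydrogen-bond donors and acceptors and differ in ring size and hetero atom, but nothing available explains why the number rises with this change.

Going by these compounds alone, with only two groups compared at this position, it remains open whether the six-membered ring, the ring nitrogen, or both set the difference, and a phenyl or a thiophen-2-yl group here would help to separate these possibilities. Going by these compounds, it also remains open whether furan-2-yl would give a step of similar size and direction alongside the methoxy group of compound 3 or the methyl group of compound 1.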